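A Methyl Added to the Pyridine Ring

The source may hold more compounds than are shown below. What is called first, only, known or untested is meant among the compounds shown, and "the series" means these compounds.

Measured so far:
compound 1, `c1coc(-c2ccccc2NCC2=NCCN2)c1`: 0.468 nM
compound 2, `Cc1ccc(-c2ccccc2NCC2=NCCN2)o1`: 2.69 nM
compound 3, `c1ccc(-c2ccccc2NCC2=NCCN2)nc1`: 6.76 nM

These three compounds were tested in a functional assay for activation of Alpha-1A adrenergic receptor (Homo sapiens), read by calcium flux; on this read-out higher numbers stand for an effect only at larger amounts of compound and lower numbers for an effect already at smaller amounts. Compound 3 stands highest of the three, and its step from compound 1, a 14-fold higher number from compound 1 to compound 3 (1.16 log units; beyond the scatter), is the largest one measured. The two cores differ by pyridin-2-yl in place of furan-2-yl on an aromatic carbon.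

The compound not yet measured is compound 4, `Cc1cccnc1-c1ccccc1NCC1=NCCN1`. It differs from compound 3 by methyl in place of hydrogen on an aromatic carbon. The same kind of change has already been made once, from compound 1 to compound 2: methyl in place of hydrogen on an aromatic carbon. There it gave a 5.7-fold higher number from compound 1 to compound 2 (0.76 log units; beyond the scatter). The surroundings are not identical, though: in compound 2 the methyl sits on an aromatic carbon of a five-membered aromatic ring with 1 oxygen, next to the ring oxygen, whereas in compound 4 it sits on an aromatic carbon of a six-membered aromatic ring with 1 nitrogen, ortho to a large group. On the strength of that single earlier step, compound 4 is expected to move by about a 3.0-fold higher number from compound 3 to compound 4 (0.47 log units; beyond the scatter), a somewhat smaller step than before because the step of a 5.7-fold higher number from compound 1 to compound 2 (0.76 log units; beyond the scatter) was made on a different ring. Compound 4 is therefore estimated at 20 nM, between 7 nM and 60 nM.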

Compound 4, half-maximal effective concentration: 24.6 nM
The estimate for compound 4 lay 1.2-fold (0.09 log units) below the measured number, and the stated range covers the measured number.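

Methyl in place of hydrogen on the pyridine ring gives a 3.6-fold higher number from compound 3 to compound 4 (0.56 log units; beyond the scatter) in this assay and so moves the number the same way as it did on the core of compound 1. Side by side, the two steps cannot be told apart: the same change on two cores in this assay, a 5.7-fold higher number (0.76 log units; beyond the scatter) from compound 1 to compound 2 and a 3.6-fold higher number (0.56 log units; beyond the scatter) from compound 3 to compound 4, 1.6-fold (0.20 log units) apart, within the scatter of two such steps. Within these two pairs, then, the change carried over from one core to the other, but two pairs do not make a rule for other cores, and they do not show why the number rises.

The compounds shown leave open whether a larger group in the same place, such as ethyl or methoxy, or a chlorine atom would move the number further than methyl does. Going by these compounds, whether a methyl on another carbon of the pyridine ring would give a step of similar size also stays open.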